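Replacing the bromohexyl chain: an estimate for compound 4

The source may report more compounds than this note shows. Statements on the series, on what has been measured and on what is new or still open speak of the compounds shown alone.

In a functional assay on HL-60 cells (Homo sapiens) for cytotoxicity, read by MTT assay, with a stated time of 24 h; a lower number here means a stronger inhibitor, a higher number a weaker inhibitor:
compound 1 `CN1CCN(CCCCCOc2c(Br)cc(Br)cc2Oc2ccc(Br)cc2Br)CC1`: 48.3 ug/mL
compound 2 `Brc1ccc(Oc2cc(Br)cc(Br)c2OCCCCCN2CCN(c3ccccc3)CC2)c(Br)c1`: 41.6 ug/mL
compound 3 `BrCCCCCCOc1c(Br)cc(Br)cc1Oc1ccc(Br)cc1Br`: 37.8 ug/mL

All three numbers lie within the scatter of one another, so compound 3 does not stand apart from the other two. Compound 4 `CC(C)(C)C(=O)C(C#N)Oc1c(Br)cc(Br)cc1Oc1ccc(Br)cc1Br` has not yet been measured. It carries cyano((tert-butyl)carbonyl)methyl in place of 6-bromohexyl on an oxygen on an aromatic ring.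

Within the data shown here, two measured steps bear on this change, a 1.2-fold lower number from compound 1 to compound 2 (0.06 log units; within the scatter) and a 1.3-fold lower number from compound 1 to compound 3 (0.11 log units; within the scatter), and both stay within the scatter. Among the measured compounds shown here, neither replaces the whole group on that oxygen, so they are only a loose guide, and no measured compound carries the entering group. In this assay, the expected outcome is therefore no step beyond the scatter, with a 1.1-fold lower number from compound 3 to compound 4 (0.02 log units; within the scatter) as the estimate, though with wide uncertainty. Compound 4 is estimated at 36 ug/mL (expected range 13 ug/mL to 75 ug/mL).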

Compound 4, half-maximal inhibitory concentration: 29.2 ug/mL
Estimate against measurement, compound 4: 1.2-fold (0.09 log units) above; measured number inside the range.
By their numbers in this assay, from the lowest: compounds 4, 3, 2 and 1 (each within the scatter of the next).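

In this assay, among these compounds, the earlier steps changed only part of the group on the oxygen on an aromatic ring, whereas here the whole 6-bromohexyl group gives way to cyano((tert-butyl)carbonyl)methyl, with a 1.3-fold lower number from compound 3 to compound 4 (0.11 log units; within the scatter). This shows that the number stays within the scatter even when the entering group has a carbonyl and a nitrile, no bromine, and a different chain. No measurement shown here offers an explanation for this result.

The four compounds therefore do not show whether any group on that oxygen can move the number beyond the scatter. On these data alone, a carboxylic acid or a primary amine on the chain remains open, as does a plain methyl on that oxygen.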